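Working notes: from compound 3 to compound 4

The source may report more compounds than this note shows. Statements on the series, on what has been measured and on what is new or still open speak of the compounds shown alone.

compound 1 `COc1cc(NC(C)CCCNC(=O)Nc2cccc(F)c2)c2ncccc2c1` — 18000 nM
compound 2 `COc1cc(NC(C)CCCNC(=O)Nc2cccc(Cl)c2)c2ncccc2c1` — 17000 nM
compound 3 `COc1cc(NC(C)CCCNC(=O)NNC(=O)Nc2ccc(C(F)(F)F)cc2)c2ncccc2c1` — 15000 nM

All three numbers come from a functional assay on HeLa cells (Homo sapiens) for inhibition, read by MTT assay, with a stated time of 72 h; on this read-out lower numbers stand for stronger inhibition and higher numbers for weaker inhibition. Compound 3 holds the lowest number of the three, but its gaps to compound 2 and to compound 1 are within the scatter, so no order among them can be read. For the measured compounds named here, the single measured step, a 1.1-fold lower number from compound 1 to compound 2 (0.02 log units; within the scatter), is within the scatter as well. Compound 4 `COc1cc(NC(C)CCCNC(=O)NNC(=O)Nc2cccc(Cl)c2)c2ncccc2c1` differs from compound 3 by 3-chlorophenyl in place of 4-(trifluoromethyl)phenyl on an amide-type nitrogen. Going by the values given here, no measured step exchanges the aryl group on the amide-type nitrogen; the only halogen change, a 1.1-fold lower number from compound 1 to compound 2 (0.02 log units; within the scatter), was flat, and all three numbers lie close together. The expectation for this assay is therefore a step of a 1.1-fold higher number from compound 3 to compound 4 (0.03 log units; within the scatter), none beyond the scatter. Compound 4 is expected at 16000 nM, with a range from 8000 nM to 32000 nM.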

Compound 4, half-maximal inhibitory concentration: 44000 nM
Compound 4: middle estimate off by 2.8-fold (0.44 log units), on the low side; the measured number lies above the stated range.
By their numbers in this assay, from the lowest: compounds 3, 2 and 1 (each within the scatter of the next); then compound 4.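

In this assay, for the compounds shown here, the aryl group on the amide-type nitrogen is the first place where a change moves the number beyond the scatter, with 3-chlorophenyl in place of 4-(trifluoromethyl)phenyl (a 2.9-fold higher number from compound 3 to compound 4 (0.47 log units; beyond the scatter)). Placing ((3-chlorophenyl)carbamoyl)amino on that nitrogen also gives modest steps (a 2.6-fold higher number from compound 2 to compound 4 (0.41 log units; beyond the scatter); a 2.4-fold higher number from compound 1 to compound 4 (0.39 log units; beyond the scatter)), though compound 3, which carries a similar longer link, stays within the scatter of compounds 1 and 2. No measurement shown bears on the reason for these steps.

The compounds shown do not separate the loss of trifluoromethyl from the arrival of chloro, since both change in a single step. As far as these compounds go, how a nitrile or a carboxylic acid on that aryl ring would read remains open.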